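The source may hold more compounds than are shown below. What is called first, only, known or untested is meant among the compounds shown, and "the series" means these compounds.

Measured so far in a functional assay on 1321-N1 cells for agonist activity at P2Y purinoceptor 6 (Homo sapiens), read by scintillation counting and inositol phosphate accumulation; a higher number here means that more compound is needed for the effect, a lower number that less compound is needed:
compound 1 `O=c1[nH]/c(=N\OCCCCc2ccccc2)ccn1[C@@H]1O[C@H](COP(=O)(O)OP(=O)(O)OP(=O)(O)O)[C@@H](O)[C@H]1O` gives 251 nM;
compound 2 `O=c1[nH]/c(=N\OCCCc2ccc(F)cc2)ccn1[C@@H]1O[C@H](COP(=O)(O)OP(=O)(O)OP(=O)(O)O)[C@@H](O)[C@H]1O` gives 1210 nM.

For the measured compounds named here, compound 2 stands at the higher of the two numbers; the step of a 4.8-fold higher number from compound 1 to compound 2 (0.68 log units; beyond the scatter) sets it well apart from compound 1, and no other measured compound lies nearer to it. Compound 3 `O=c1[nH]/c(=N\OCCCc2cccc([N+](=O)[O-])c2)ccn1[C@@H]1O[C@H](COP(=O)(O)OP(=O)(O)OP(=O)(O)O)[C@@H](O)[C@H]1O` has not yet been measured in this assay. It differs from compound 2 by 3-nitrophenyl in place of 4-fluorophenyl on a saturated chain carbon, three bonds along the chain from an oxygen; the chain between the oxygen and the ring is kept, so the whole change sits on the ring.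

Going by the values given here, only one measured step exists, a 4.8-fold higher number from compound 1 to compound 2 (0.68 log units; beyond the scatter), and it alters chain length and ring substitution at once. It gives no separate reading on a swap of one ring substituent for another at a fixed chain length. Nothing measured therefore supports a step beyond the scatter in either direction, and the expectation for compound 3 is a number near that of compound 2, with wide uncertainty. For compound 3 the estimate in this assay is 1200 nM, with a range from 350 nM to 4500 nM. This corresponds to an expected step of a 1.0-fold lower number from compound 2 to compound 3 (0.00 log units; within the scatter).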

Compound 3, half-maximal effective concentration: 9700 nM
Estimate against measurement, compound 3: 8.1-fold (0.91 log units) below; the measured number lies above the stated range.
By their numbers in this assay, from the lowest: compound 1; then compound 2; then compound 3.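

With the chain held fixed, this assay gives a reading on the ring alone: 3-nitrophenyl in place of 4-fluorophenyl brings an 8.0-fold higher number from compound 2 to compound 3 (0.90 log units; beyond the scatter), so this position responds to ring substitution without any change in chain length, which the earlier pair could not show because it altered both at once. The widest gap in the series is now a 39-fold higher number from compound 1 to compound 3 (1.59 log units; beyond the scatter), and compound 3 holds the highest number of the three, with its steps to both other compounds printed as beyond the scatter. Nothing measured here explains why this swap raises the number.

The swap changes both the substituent and its place on the ring, so the compounds shown do not separate the effect of nitro in place of fluoro from that of the 3-position in place of the 4-position; 4-nitrophenyl and 3-fluorophenyl on the same chain would divide the two. Also open, as far as these compounds go, is how a ring carrying an amine or a carboxylic acid would read at this position, and whether 3-nitrophenyl on the longer chain of compound 1 would keep the same step.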